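A few compounds are considered here, and "the series" means these few. Any claim that something is new, unique, unknown or untested is made for them only; others in the source may bear on it.

Three compounds in this set have been examined in a functional assay on A9 cells for agonist activity at Free fatty acid receptor 1 (Homo sapiens), read by inositol phosphate accumulation (a lower number here means that less compound is needed, a higher number that more compound is needed for the effect), and for compound 3 the outcome is "not determined" (no result reported). Compound 1 `Cc1cc(Cl)ccc1-c1cccc(COc2ccc([C@H](CC(=O)O)c3nccn3C)cc2)c1` gives 7.6 nM in this assay. Compound 2 `Cc1nc(-c2ccc(C(F)(F)F)cc2)sc1COc1ccc([C@H](CC(=O)O)c2nccn2C)cc1`, which shares the acid-bearing side chain and the methylimidazole but carries a different aryl ether on the far side, gives 16 nM. Compound 3 `Cc1nc(-c2ccc(C(F)(F)F)cc2)sc1COc1ccc([C@H](CC(=O)O)c2ncnn2C)cc1` keeps the whole framework of compound 2 and replaces the imidazole with a 1-methyl-1H-1,2,4-triazol-5-yl group; for compound 3 this assay reports "not determined" (no result reported), so its standing cannot be placed against the other two. Compound 4 `Cc1nc(-c2ccc(C(F)(F)F)cc2)sc1COc1ccc([C@H](CC(=O)O)c2nnnn2C)cc1` takes the same framework one nitrogen further: 1-methyl-1H-tetrazol-5-yl in place of 1-methyl-1H-1,2,4-triazol-5-yl on a saturated chain carbon bound to an aromatic carbon and a saturated chain carbon. For the measured compounds named here, because compound 3 has no value, the only anchor for this step is compound 2 at 16 nM, and the change from a three-nitrogen ring to a four-nitrogen ring of the same size and shape offers no basis for expecting a large move in either direction beyond the usual scatter, though the absence of any measured step leaves the expectation loose. Compound 4 is expected to give about 40 nM in this assay, within a range of 8 nM to 300 nM.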

Compound 4, half-maximal effective concentration: 3.8 nM
Compound 4: middle estimate off by 11-fold (1.02 log units), on the high side; measured number below the stated range.
By their numbers in this assay, from the lowest: compounds 4 and 1 (each within the scatter of the next); then compound 2.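

On the saturated chain carbon bound to an aromatic carbon and a saturated chain carbon, putting 1-methyl-1H-tetrazol-5-yl in place of 1-methyl-1H-imidazol-2-yl gives, in this assay, a 4.2-fold lower number from compound 2 to compound 4 (0.62 log units; beyond the scatter). For the compounds shown here, this is the first single-place change that can be read in this set, and it shows that this position accepts a ring richer in nitrogen without any loss, with a modest gain in the number. Compound 3, which carries 1-methyl-1H-1,2,4-triazol-5-yl, has no reported result, so the step from it to compound 4 cannot be read, and nothing measured here bears on what lies behind the step from the imidazole to the tetrazole.

The compounds shown leave open whether 1-methyl-1H-tetrazol-5-yl would give a similar step on the framework of compound 1, where only the imidazole appears. They also leave open how this position would respond to a plain phenyl ring, or to an ethyl group in place of the methyl on the tetrazole.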